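Methoxy Substitution on Two Stilbene-like Azole Scaffolds

The source may hold more compounds than are shown below. What is called first, only, known or untested is meant among the compounds shown, and "the series" means these compounds.

Measured compounds:
compound 1, `COc1ccc(/C=C/c2cc(C)n[nH]2)cc1`, 8400 nM
compound 2, `COc1ccc(/C=C/c2cc(C)n[nH]2)cc1OC`, 22400 nM
compound 3, `Cc1cc(/C=C/c2ccc(O)cc2)on1`, 44200 nM

Of the compounds shown here, three have been tested in a functional assay on S1 cells (Homo sapiens) for cytotoxicity, read by MTT assay, with a stated time of 72 h; a higher number here means a weaker inhibitor, a lower number a stronger inhibitor. Compound 1 `COc1ccc(/C=C/c2cc(C)n[nH]2)cc1` gives 8400 nM in this assay, the lowest number of the three. Compound 2 `COc1ccc(/C=C/c2cc(C)n[nH]2)cc1OC` carries one added group on the same core, and the step of a 2.7-fold higher number from compound 1 to compound 2 (0.43 log units; beyond the scatter) marks the change (methoxy in place of hydrogen on an aromatic carbon). Compound 3 `Cc1cc(/C=C/c2ccc(O)cc2)on1` is built on a different core; how the cores of compound 1 and compound 3 differ is not broken down here. In this assay compound 3 gives 44200 nM, which lies within the scatter of the number for compound 2 and beyond the scatter above that for compound 1.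

Compound 4 `COc1cc(/C=C/c2cc(C)no2)ccc1O` has not yet been measured. It differs from compound 3 by methoxy in place of hydrogen on an aromatic carbon. Among the compounds with values here, this is the same kind of change as the one from compound 1 to compound 2, though the surroundings differ: in compound 4 the entering methoxy is ortho to a hydroxy group, whereas in compound 2 it is ortho to a methoxy group. Resting on the step from compound 1 to compound 2, a comparable step is expected for compound 4, giving a 1.8-fold higher number from compound 3 to compound 4 (0.26 log units; within the scatter) in this assay. Within the data shown here, the single precedent and the different core leave this expectation loose. Compound 4 is therefore estimated at 80000 nM in this assay, with a range from 30000 nM to 200000 nM.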

Compound 4, half-maximal inhibitory concentration: 50500 nM
Beside the measured number, compound 4's estimate is 1.6-fold (0.20 log units) above it, and the stated range covers the measured number.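

In this assay, methoxy in place of hydrogen on an aromatic carbon gives a 1.1-fold higher number from compound 3 to compound 4 (0.06 log units; within the scatter), so on this core the two numbers cannot be told apart. Set beside the earlier step on the core of compound 1, the result gives no sign that the change behaves differently on the two cores: the same change on two cores in this assay, a 2.7-fold higher number (0.43 log units; beyond the scatter) from compound 1 to compound 2 and a 1.1-fold higher number (0.06 log units; within the scatter) from compound 3 to compound 4, 2.3-fold (0.37 log units) apart, within the scatter of two such steps. This does not show that the step carries over unchanged, since one step lies beyond the scatter and the other within it, and a single pair on each core cannot separate the effect of the core from that of the surroundings, as the methoxy in compound 4 stands ortho to a hydroxy group.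

The compounds shown leave open whether an amine, a carboxylic acid or a longer chain such as ethoxy, placed on the same aromatic carbon, would give a step beyond the scatter on either core. They also leave open how the number on the core of compound 3 would respond if a methoxy group took the place of the hydroxy group, which would allow a closer match with the pair on the core of compound 1.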